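A few compounds are considered here, and "the series" means these few. Any claim that something is new, unique, unknown or untested is made for them only; others in the source may bear on it.

In a functional assay on A549 cells (Homo sapiens) for cytotoxicity, read by sulforhodamine B assay, with a stated time of 72 h (a lower number here means that less compound is needed, a higher number that more compound is needed for the effect), two compounds built on a shared core have been measured so far. Compound 1 `Cc1cccc(-c2cc3occ(C)c3c(=O)o2)c1` gives 53.8 uM, and compound 2 `Cc1coc2cc(-c3cccc(O)c3)oc(=O)c12` gives 68.6 uM. These two values lie within the scatter of each other, so compound 2 cannot be ranked against compound 1.

Compound 3 `Cc1coc2cc(-c3ccc(O)c(O)c3)oc(=O)c12` differs from compound 2 at one place: hydroxy in place of hydrogen on an aromatic carbon. Hydroxy stands in place of hydrogen on an aromatic carbon, ortho to a hydroxy group and para to a large group.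

Within the data shown here, only one measured step bears on this change, and only loosely: a 1.3-fold higher number from compound 1 to compound 2 (0.11 log units; within the scatter). That exchange put hydroxy in place of methyl on an aromatic carbon, whereas here hydrogen is what leaves. Among the measured compounds shown here, with this single small step as the only guide, no change beyond the scatter is expected in this assay, and no direction can be firmly favoured. The estimated step is a 1.2-fold lower number from compound 2 to compound 3 (0.10 log units; within the scatter). For compound 3 the expected value is 55 uM, with an estimated range from 22 uM to 120 uM.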

Compound 3, concentration for half-maximal effect: 19.4 uM
For compound 3 the middle estimate is 2.8-fold (0.45 log units) above the measured one, and the stated range ends above it.
By their numbers in this assay, from the lowest: compound 3; then compounds 1 and 2 (each within the scatter of the next).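

In this assay, hydroxy in place of hydrogen on the aromatic carbon that lies ortho to a hydroxy group and para to a large group gives a 3.5-fold lower number from compound 2 to compound 3 (0.55 log units; beyond the scatter), a modest step but the first one here that lies beyond the scatter. The earlier exchange of methyl for hydroxy on the same six-membered aromatic ring of carbon only gave a 1.3-fold higher number from compound 1 to compound 2 (0.11 log units; within the scatter), so that step alone could not show that the number responds to a change on this ring. This new position does show such a response, and adding hydroxy here moves the number towards less compound being needed. Nothing given here accounts for this shift.

The compounds shown leave open whether a methoxy group, an amine or a fluorine atom on this carbon would move the number as hydroxy does. Among these compounds, they also leave open whether the step depends on the hydroxy group ortho to this carbon, since the only step at this place starts from compound 2, which already carries that group.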